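This account rests on a few compounds, and the source may have more. Where it says the series, first, only, none or still open, it means among the compounds named here.

Measured in a functional assay on ECa-109 cells (Homo sapiens) for antiproliferative activity, read by MTT assay, with a stated time of 72 h; a higher number here means a weaker inhibitor, a lower number a stronger inhibitor:
Compound 1 `CCCSc1nc(N/N=C/c2ccc(Cl)cc2)c2nnn(Cc3ccccc3)c2n1`: > 64000 nM (a limit)
Compound 2 `CCCSc1nc(N/N=C/c2c[nH]c3ccccc23)c2nnn(Cc3ccccc3)c2n1`: 8690 nM

Going by the values given here, compound 2 holds the only true number in this assay so far. The value of compound 1 is a limit. Compound 3 `CCCSc1nc(N/N=C/c2ccc(N(C)C)cc2)c2nnn(Cc3ccccc3)c2n1` carries 4-(dimethylamino)phenyl in place of 1H-indol-3-yl on a carbon with a double bond to nitrogen. Among the compounds with values here, one measured step bears on this. Because of an at least 7.3-fold lower number from compound 1 to compound 2 (0.86 log units; beyond the scatter) on trading 4-chlorophenyl for 1H-indol-3-yl, giving up 1H-indol-3-yl for another substituted phenyl is expected to raise the number. The expected change is a 3.0-fold higher number from compound 2 to compound 3 (0.48 log units; beyond the scatter) in this assay and would lie beyond the scatter. Compound 3 is estimated at 26000 nM within an expected range from 9000 nM to 64000 nM.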

Compound 3, half-maximal inhibitory concentration: 20000 nM
The estimate for compound 3 lay 1.3-fold (0.11 log units) above the measured number; measured number inside the range.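

In this assay, a substituted phenyl on the carbon with a double bond to nitrogen need not lose all activity: dimethylamino in place of chloro on an aromatic carbon gives an at least 3.2-fold lower number from compound 1 to compound 3 (0.50 log units; beyond the scatter) and shows that the phenyl's substituent matters. 1H-indol-3-yl still keeps an edge, with a 2.3-fold higher number from compound 2 to compound 3 (0.36 log units; beyond the scatter) on giving it up for 4-(dimethylamino)phenyl. The gain over compound 1 is only a bound, since the value of compound 1 is a limit: the limit of > 64000 nM in this assay, at which 1 of the 3 values shown sits. The compounds shown leave open whether a primary amine or a methoxy group in place of dimethylamino would lower the number as well.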